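Cyclohexyl for ethyl on the amine carbon: an unreadable step

The source may report more compounds than this note shows. Statements on the series, on what has been measured and on what is new or still open speak of the compounds shown alone.

Compound 1, `FC1(F)CCC(CN(C[C@H]2Cc3c(cccc3N3CCNCC3)CN2)[C@H]2CCCc3cccnc32)CC1`, gives in a functional assay on CCRF-CEM cells for agonist activity at C-X-C chemokine receptor type 4 (Homo sapiens), read by calcium flux, with a stated time of 25 min (a higher number here means that more compound is needed for the effect, a lower number that less compound is needed), a result of > 30000 nM, which is a limit of the assay and not a number.
Compound 2, `CCN(C[C@H]1Cc2c(cccc2N2CCNCC2)CN1)[C@H]1CCCc2cccnc21`, gives in this assay a result of > 30000 nM, again a limit.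
Compound 3, `CCCN(C[C@H]1Cc2c(cccc2N2CCNCC2)CN1)[C@H]1CCCc2cccnc21`, gives in this assay a result of > 30000 nM, also a limit.

Compound 3 therefore stands at the edge of what this assay can report, and so do the other two compounds: the limit of > 30000 nM in this assay, at which 3 of the 3 values shown sit. No real number exists for any of them.

Compound 4 is `c1cnc2c(c1)CCC[C@@H]2N(CC1CCCCC1)C[C@H]1Cc2c(cccc2N2CCNCC2)CN1`. The change from compound 3 is cyclohexyl in place of ethyl on a saturated chain carbon bound to an amine nitrogen, in words cyclohexyl in place of ethyl on a saturated chain carbon bound to an amine nitrogen. The nearest measured steps are a step that the two limits leave unreadable from compound 1 to compound 3 and a step that the two limits leave unreadable from compound 2 to compound 3, both of which run between limits and so cannot be given a size or a direction. Compound 1 carries a ring at the same place as compound 4 and still sits at the limit.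

On this basis compound 4 is expected to give a limit as well, with a number no higher from compound 3 to compound 4 (the limit leaves the size open) as the step that this expectation means. The estimate for compound 4 in this assay is 30000 nM, within 10000 nM to 100000 nM.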

Compound 4, half-maximal effective concentration: > 30000 nM
Compound 4: a limit, no number (the forecaster's own chance of this, stated with the estimate: 80%); the middle value lies on the limit itself.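

Compound 4 ends at a limit of the assay, as do compound 1, compound 2 and compound 3, so no step among these four compounds can be read, in size or in direction. All four share one edge: the limit of > 30000 nM in this assay, at which 4 of the 4 values shown sit.

The compounds shown leave open how the groups at this place compare in this assay, and what concentration any of the four actually needs.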